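Swapping the group on the four-membered ring of compound 3

The source may hold more compounds than are shown below. What is called first, only, known or untested is meant among the compounds shown, and "the series" means these compounds.

Compound 3 `CS(=O)(=O)N1CCN(C2CN(CCC3(c4ccc(Cl)c(Cl)c4)CCC(=O)N(CC4CC4)C3)C2)CC1` gives 3.16 nM in an assay on isolated protein (artery, Oryctolagus cuniculus) with Substance-P receptor (Homo sapiens) as the target (a lower number here means tighter binding, a higher number weaker binding), the highest number among the three measured compounds. Compound 1 `CS(=O)(=O)N1CCN(C2CN(CCC3(c4ccc(Cl)c(Cl)c4)CCC(=O)N(Cc4ccccc4)C3)C2)CC1` gives 0.631 nM in this assay, and compound 2 `O=C1CCC(CCN2CC(N3CCC(O)CC3)C2)(c2ccc(Cl)c(Cl)c2)CN1Cc1ccccc1` gives 0.0794 nM in this assay. The step of a 5.0-fold higher number from compound 1 to compound 3 (0.70 log units; beyond the scatter) separates compound 3 from its nearest neighbour, while the step of a 7.9-fold lower number from compound 1 to compound 2 (0.90 log units; beyond the scatter) shows how much the group on the four-membered ring can move the number.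

Compound 4 `CS(=O)(=O)NC1CCN(C2CN(CCC3(c4ccc(Cl)c(Cl)c4)CCC(=O)N(CC4CC4)C3)C2)CC1` differs from compound 3 in one place: 4-(methanesulfonamido)piperidin-1-yl in place of 4-(methylsulfonyl)piperazin-1-yl on a saturated ring carbon. The measured step that bears on this is the earlier exchange of the same leaving group, a 7.9-fold lower number from compound 1 to compound 2 (0.90 log units; beyond the scatter). There the entering group was a piperidine carrying a hydroxyl, whereas here it is a piperidine carrying a methanesulfonamide, so only the direction can be borrowed with confidence, and a smaller move than that one seems the safer expectation. A lower number beyond the scatter is therefore expected, a 3.2-fold lower number from compound 3 to compound 4 (0.50 log units; beyond the scatter). Compound 4 is estimated at 1 nM, within a range from 0.3 nM to 3.5 nM.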

Compound 4, dissociation constant: 10 nM
Beside the measured number, compound 4's estimate is 10-fold (1.00 log units) below it, outside the stated range (above it).
By their numbers in this assay, from the lowest: compound 2; then compound 1; then compound 3; then compound 4.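

On a saturated ring carbon of the four-membered ring, the exchange of 4-(methylsulfonyl)piperazin-1-yl for a piperidine need not lower the number: in this assay, 4-(methanesulfonamido)piperidin-1-yl gives a 3.2-fold higher number from compound 3 to compound 4 (0.50 log units; beyond the scatter), the opposite direction to the step with 4-hydroxypiperidin-1-yl, a 7.9-fold lower number from compound 1 to compound 2 (0.90 log units; beyond the scatter). What the entering piperidine carries therefore matters as much as the leaving group, although those two steps also differ in the group on the amide-type nitrogen, phenyl in one pair and cyclopropyl in the other, so the two influences cannot be separated. Nothing available accounts for the direction of the new step.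

Going by these compounds, it remains open whether 4-hydroxypiperidin-1-yl would lower the number alongside cyclopropyl as it does alongside phenyl. On these data alone, how a piperidine carrying a plain amine, 4-aminopiperidin-1-yl, would compare at this place also stays unknown.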